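A few compounds are considered here, and "the series" means these few. Any claim that something is new, unique, unknown or untested is made for them only; others in the source may bear on it.

Measured compounds:
- Compound 1 `C[C@H]1CC[C@@H]2[C@@H](OC(=O)[C@]23CC(c2ccc(Cl)cc2)=NO3)[C@]2(C)C(=O)C=C[C@@]12O` gives 43000 nM
- Compound 2 `C[C@H]1CC[C@@H]2[C@@H](OC(=O)[C@]23CC(c2ccccc2)=NO3)[C@]2(C)C(=O)C=C[C@@]12O` gives 39800 nM
- Compound 3 `C[C@H]1CC[C@@H]2[C@@H](OC(=O)[C@]23CC(c2ccc([N+](=O)[O-])cc2)=NO3)[C@]2(C)C(=O)C=C[C@@]12O` gives 7000 nM

In a functional assay on DU-145 cells (Homo sapiens) for cytotoxicity, read by sulforhodamine B assay, with a stated time of 48 h (on this read-out lower numbers stand for stronger inhibition and higher numbers for weaker inhibition), compound 2 gives 39800 nM and cannot be told apart from compound 1, as a 1.1-fold lower number from compound 1 to compound 2 (0.03 log units; within the scatter) shows. Compound 3 stands clearly apart, with a 5.7-fold lower number from compound 2 to compound 3 (0.75 log units; beyond the scatter).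

The next compound, compound 4 `C[C@H]1CC[C@@H]2[C@@H](OC(=O)[C@]23CC(c2ccccc2F)=NO3)[C@]2(C)C(=O)C=C[C@@]12O`, has fluoro in place of hydrogen on an aromatic carbon, ortho to a large group: fluoro in place of hydrogen on an aromatic carbon. Going by the values given here, no measured compound carries fluoro, so the evidence is indirect. The closest comparison is the exchange between chloro and hydrogen, a 1.1-fold lower number from compound 1 to compound 2 (0.03 log units; within the scatter), which involves another single halogen on the aromatic ring. The nitro exchange, a 6.1-fold lower number from compound 1 to compound 3 (0.79 log units; beyond the scatter), shows that a change on this ring can shift the number, but it is a less close comparison. The expected result is a 1.1-fold lower number from compound 2 to compound 4 (0.06 log units; within the scatter), which would be no step beyond the scatter. For compound 4 the estimated value is 35000 nM, with an expected range of 14000 nM to 70000 nM.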

Compound 4, half-maximal inhibitory concentration: 24000 nM
Beside the measured number, compound 4's estimate is 1.5-fold (0.16 log units) above it; the measured number falls inside the stated range.
By their numbers in this assay, from the lowest: compound 3; then compounds 4, 2 and 1 (each within the scatter of the next).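

In this assay, going by these compounds alone, the first change at this place on the ring, ortho to a large group, gives a 1.7-fold lower number from compound 2 to compound 4 (0.22 log units; within the scatter), so adding fluoro here leaves the number within the scatter of the unsubstituted phenyl compound. The 2-fluorophenyl and 4-chlorophenyl compounds also cannot be told apart, with a 1.8-fold lower number from compound 1 to compound 4 (0.25 log units; within the scatter), whereas the 4-nitrophenyl compound stays clearly separate, with a 3.4-fold higher number from compound 3 to compound 4 (0.54 log units; beyond the scatter). Nothing measured here accounts for these numbers.

The compounds shown leave open whether the separation of compound 3 is specific to nitro or would also appear with another group on the ring, such as an amine or a methoxy group. They also leave open whether fluoro would give a similar number elsewhere on the ring.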